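The source may report more compounds than this note shows. Statements on the series, on what has been measured and on what is new or still open speak of the compounds shown alone.

Compound 1 `O=C(Nc1ccc(S(F)(F)(F)(F)F)cc1)c1ccc(Sc2ccc(O)cc2)cc1` and compound 2 `O=C(Nc1ccc(S(F)(F)(F)(F)F)cc1)c1ccc(S(=O)(=O)c2ccc(O)cc2)cc1` share a core and differ only in the sulfur link. In a functional assay on LNCaP cells (Homo sapiens) for antiproliferative activity, read by fluorescence and propidium iodide staining, with a stated time of 96 h (a higher number here means a weaker inhibitor, a lower number a stronger inhibitor), compound 1 gives 4860 nM, and compound 2 gives 2490 nM. The step of a 2.0-fold lower number from compound 1 to compound 2 (0.29 log units; within the scatter) leaves the two within the scatter of each other, so compound 2 stands beside compound 1 rather than apart from it. Compound 3 `O=C(Nc1ccc(C(F)(F)F)cc1)c1ccc(S(=O)(=O)c2ccc(O)cc2)cc1` is the next step: a group of 4 heavy atoms (1 carbon, 3 fluorine; no ring) in place of a group of 6 heavy atoms (5 fluorine, 1 sulfur; no ring), on an aromatic carbon. Among the compounds with values here, no measured step bears on this change; the only step recorded, from compound 1 to compound 2, concerns the sulfur link and not this end of the molecule. The expectation for compound 3 therefore rests on compound 2 alone, with no basis for a step beyond the scatter in either direction: the step is estimated as a 1.2-fold higher number from compound 2 to compound 3 (0.08 log units; within the scatter). Compound 3 is accordingly estimated at 3000 nM, with a range from 1200 nM to 8000 nM.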

Compound 3, half-maximal inhibitory concentration: 10800 nM
Estimate against measurement, compound 3: 3.6-fold (0.56 log units) below; measured number above the stated range.
By their numbers in this assay, from the lowest: compounds 2 and 1 (each within the scatter of the next); then compound 3.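

On the aromatic carbon para to a large group, the choice of group matters in this assay: putting trifluoromethyl in place of the group of 6 heavy atoms (5 fluorine, 1 sulfur) gives a 4.3-fold higher number from compound 2 to compound 3 (0.64 log units; beyond the scatter). The change in the sulfur link, by contrast, gave only a 2.0-fold lower number from compound 1 to compound 2 (0.29 log units; within the scatter), so this is the first change among these compounds to move the number beyond the scatter. Nothing measured here accounts for the loss, and neither group carries a hydrogen-bond donor, a hydrogen-bond acceptor or a net charge.

The compounds shown leave open how a nitrile, an amine or a carboxylic acid would fare at this place. They also leave open whether trifluoromethyl would give a similar step with the sulfanyl link of compound 1.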